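The source may report more compounds than this note shows. Statements on the series, on what has been measured and on what is new or still open speak of the compounds shown alone.

Measured compounds in this series:

Compound 1 `N#Cc1ccc(Nc2nccc(Oc3ccc(-c4ccc(C#N)cc4)cc3Cl)n2)cc1` — > 295000 nM, a limit of the assay
Compound 2 `N#Cc1ccc(Nc2nccc(Oc3ccc(-c4ccc(C#N)cc4)c(Cl)c3)n2)cc1` — 31100 nM
Compound 3 `Cc1cc(-c2ccc(C#N)cc2)c(Cl)cc1Oc1ccnc(Nc2ccc(C#N)cc2)n1` — > 285000 nM, a limit of the assay

All three were tested in a functional assay on MT4 cells (Homo sapiens) for cytotoxicity, read by MTT assay, with a stated time of 5 days; a lower number here means that less compound is tolerated, a higher number that more compound is tolerated. Compound 2 gives 31100 nM. Compound 1 sits at a limit, > 295000 nM. Compound 3 likewise sits at a limit, > 285000 nM. Compound 1 and compound 2 have the same atoms joined differently; the difference between the two cores is not broken down here.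

From compound 2 to compound 3 the change is methyl in place of hydrogen on an aromatic carbon, and it gave an at least 9.1-fold higher number from compound 2 to compound 3 (0.96 log units; beyond the scatter). Compound 4 `Cc1cc(-c2ccc(C#N)cc2)cc(Cl)c1Oc1ccnc(Nc2ccc(C#N)cc2)n1` is formed from compound 1 by methyl in place of hydrogen on an aromatic carbon. The surroundings differ: in the measured pair the methyl is para to a chloro group, here it is meta to a chloro group, so this is the same kind of change, not the same change.

Compound 1 already sits at the limit of > 295000 nM in this assay, at which 1 of the 3 values shown sits. Compound 4 is expected to stay at a limit as well, an estimated step that the limit leaves unreadable from compound 1 to compound 4, resting on that limit and on the rise seen in an at least 9.1-fold higher number from compound 2 to compound 3 (0.96 log units; beyond the scatter). Compound 4 is therefore estimated at 300000 nM, between 150000 nM and 600000 nM.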

Compound 4, half-maximal cytotoxic concentration: > 285000 nM
Compound 4: no number, only a limit; the forecaster's own chance of this, stated with the estimate: 80%; the middle value is on the limit's open side.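

Compound 1 and compound 4 both sit at a limit in this assay, and the step between them cannot be read. The compounds shown leave open whether the methyl on compound 4 changes how much compound is tolerated.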